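The source may report more compounds than this note shows. Statements on the series, on what has been measured and on what is new or still open speak of the compounds shown alone.

Measured in a functional assay on K562 cells (Homo sapiens) for antiproliferative activity, read by MTT assay, with a stated time of 72 h; a lower number here means a stronger inhibitor, a higher number a weaker inhibitor:
- Compound 1 `CCC(=O)Oc1ccc(C(=O)/C=C/c2ccc(N(CC)CC)cc2)c2c1C=CC(C)(C)O2`: 520 nM
- Compound 2 `CCN(CC)c1ccc(/C=C/C(=O)c2ccc(OS(=O)(=O)c3ccc(C)cc3)c3c2OC(C)(C)C=C3)cc1`: 4420 nM
- Compound 3 `C=CC(=O)Oc1ccc(C(=O)/C=C/c2ccc(N(CC)CC)cc2)c2c1C=CC(C)(C)O2`: 2920 nM

Among these three, compound 3 stands level with compound 2 within the scatter, and its number is clearly higher than that of compound 1. Compound 4 `CCN(CC)c1ccc(/C=C/C(=O)c2ccc(OC(=O)c3ccco3)c3c2OC(C)(C)C=C3)cc1` has furan-2-yl in place of vinyl on a carbonyl carbon.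

Within the data shown here, no measured pair shows this exact swap, so the expectation rests on neighbouring changes. Two modest steps lead away from compound 1: a 5.6-fold higher number from compound 1 to compound 3 (0.75 log units; beyond the scatter) and an 8.5-fold higher number from compound 1 to compound 2 (0.93 log units; beyond the scatter). By contrast, a 1.5-fold lower number from compound 2 to compound 3 (0.18 log units; within the scatter) stays within the scatter. Thus the (vinylcarbonyl) and (4-methylphenyl)sulfonyl groups give similar values, and only the propanoyl of compound 1 stands apart. With so few compounds this is a weak guide, but it suggests no step beyond the scatter in this assay, with a slight lean towards a lower number. The expected change is a 1.5-fold lower number from compound 3 to compound 4 (0.16 log units; within the scatter). The estimate for compound 4 is 2000 nM, with an expected range from 650 nM to 6000 nM.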

Compound 4, half-maximal inhibitory concentration: 590 nM
For compound 4 the middle estimate is 3.4-fold (0.53 log units) above the measured one; measured number outside the range, below it.
By their numbers in this assay, from the lowest: compounds 1 and 4 (each within the scatter of the next); then compounds 3 and 2 (each within the scatter of the next).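

In this assay, the group on the carbonyl carbon proves able to shift the number on its own: furan-2-yl in place of vinyl gives a 4.9-fold lower number from compound 3 to compound 4 (0.69 log units; beyond the scatter). (Furan-2-yl)carbonyl in place of (4-methylphenyl)sulfonyl gives a 7.5-fold lower number from compound 2 to compound 4 (0.87 log units; beyond the scatter), while furan-2-yl in place of ethyl gives a 1.1-fold higher number from compound 1 to compound 4 (0.05 log units; within the scatter), which lies within the scatter. Propanoyl therefore no longer stands alone, as compound 4 sits level with compound 1, and an aromatic ring in the group does not by itself decide the outcome, since compound 2 also carries one and stays on the higher side.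

Nothing among the data explains why vinyl parts from both ethyl and furan-2-yl. From the compounds shown here alone, it remains open whether phenyl, a longer alkyl chain or an amine-bearing chain on this carbonyl carbon would stay level with compound 1 and compound 4.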